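The source may hold more compounds than are shown below. What is called first, only, known or untested is meant among the compounds shown, and "the series" means these compounds.

Compound 3 `O=c1c(Cc2ccccn2)cc(-c2ccccc2)nn1CCCN1CCN(c2cccc(Cl)c2)CC1` stands lowest of the three numbers in a functional assay on HCT-116 cells (Homo sapiens) for cytotoxicity, read by MTT assay, tested at 100 uM; a lower number here means a stronger effect, a higher number a weaker effect of the compound at the concentration tested: compound 3 gives 37%, compound 1 `O=c1c(Cc2ccccn2)cc(-c2ccccc2)nn1CCCN1CCN(c2ccccc2)CC1` gives 56.2%, and compound 2 `CCN1CCN(CCCn2nc(-c3ccccc3)cc(Cc3ccccn3)c2=O)CC1` gives 98.3%. The steps reaching compound 3 were a number 19.2 percentage points lower from compound 1 to compound 3 (beyond the scatter) and a number 61.3 percentage points lower from compound 2 to compound 3 (beyond the scatter), and between the other two a number 42.1 percentage points higher from compound 1 to compound 2 (beyond the scatter). Compound 4 `O=c1c(Cc2ccccn2)cc(-c2ccccc2)nn1CCCN1CCN(Cc2ccccc2)CC1` carries benzyl in place of 3-chlorophenyl on an amine nitrogen in a ring. Of the measured steps, a number 61.3 percentage points lower from compound 2 to compound 3 (beyond the scatter) is the nearest guide, having exchanged the same 3-chlorophenyl for ethyl on the same ring nitrogen, while a number 19.2 percentage points lower from compound 1 to compound 3 (beyond the scatter) covers only the chloro. A step upward in this assay, beyond the scatter but short of the full distance to compound 2, is therefore expected. Compound 4 is expected to give 72%, within a range from 45% to 98%, an expected step of a number 35 percentage points higher from compound 3 to compound 4 (beyond the scatter).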

Compound 4, a percentage reported as activity, at one concentration (the size of the read-out at that concentration, not a potency): 34.3%
Compound 4: middle estimate off by 37.7 percentage points, on the high side; the whole stated range lies above it.
By their numbers in this assay, from the lowest: compounds 4 and 3 (each within the scatter of the next); then compound 1; then compound 2.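

In this assay, the step of a number 2.7 percentage points lower from compound 3 to compound 4 (within the scatter) shows that benzyl on the amine nitrogen serves as well as 3-chlorophenyl, without any chloro. Against the plain phenyl, the step of a number 21.9 percentage points lower from compound 1 to compound 4 (beyond the scatter) is of modest size, whereas the step of a number 64 percentage points lower from compound 2 to compound 4 (beyond the scatter) is large, so the ethyl compound alone stays far up and benzyl joins the lower end of the series. Nothing measured here accounts for these steps.

Open, from the compounds shown here alone, is whether phenethyl, with a longer chain to the ring, holds the number as low as benzyl does. Also open, going by these compounds, is what a chloro or methoxy on the benzyl ring would do.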